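The compounds below may be only part of what the source reports. "The series", "measured", "known", "first", "only" and "open" are said of these compounds alone.

Compound 1 `COc1ccc(C(C)NC(=O)/N=C(\N)NCCCc2sc(N)nc2C)cc1` gives 0.91
Compound 2 `Cc1ccc(C(C)NC(=O)/N=C(\N)NCCCc2sc(N)nc2C)cc1` gives 0.85

In a functional assay on Right cardiac atrium for agonist activity at histamine H2 receptor (Cavia porcellus), with a stated time of 30 min, in the presence of a further agent that is not named here (on this read-out lower numbers stand for smaller maximal responses and higher numbers for larger maximal responses), compound 2 stands alongside compound 1, the two separated only by a number 0.060 lower from compound 1 to compound 2 (within the scatter). Compound 3 `Cc1nc(N)sc1CCCN/C(N)=N/C(=O)NC(C)c1ccc(F)cc1` differs from compound 2 by fluoro in place of methyl on an aromatic carbon. Within the data shown here, the one measured step, a number 0.060 lower from compound 1 to compound 2 (within the scatter), exchanges groups on an aromatic carbon of the same six-membered ring of carbon only and moves the read-out no further than the scatter; no step swapping fluoro for methyl is available. By analogy, compound 3 is expected to show little change, no change at the digits printed from compound 2 to compound 3 (within the scatter), in this assay. The estimate for compound 3 is 0.85, with a range from 0.72 to 0.96.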

Compound 3, intrinsic activity: the largest response reached, as a fraction of the reference agonist's: 0.92
Beside the measured number, compound 3's estimate is 0.070 below it, and the stated range covers the measured number.
By their numbers in this assay, from the lowest: compounds 2, 1 and 3 (each within the scatter of the next).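

At this place, on an aromatic carbon para to a large group, fluoro joins methyl and methoxy in this assay with no separation beyond the scatter. Fluoro in place of methyl gives a number 0.070 higher from compound 2 to compound 3 (within the scatter) on this read-out, and fluoro in place of methoxy gives a number 0.010 higher from compound 1 to compound 3 (within the scatter) on the same read-out. Nothing available bears on a reason for this. On these data alone, whether an amine, a hydroxyl or a carboxylic acid at this place would keep the maximal response within the same range remains open.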